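One Ketone-Side Ring Swap and Its Expected Effect

The compounds below may be only part of what the source reports. "The series", "measured", "known", "first", "only" and "open" are said of these compounds alone.

Measured compounds:
compound 1 `COc1cc(OC)c(OC)cc1/C=C/C(=O)c1cc(Cl)ccc1O` — 2.23 ug/mL
compound 2 `COc1cc(OC)c(OC)cc1/C=C/C(=O)c1cccc(C(F)(F)F)c1` — 2.3 ug/mL
compound 3 `COc1cc(OC)c(OC)cc1/C=C/C(=O)c1cccc([N+](=O)[O-])c1` — 2.21 ug/mL

All three compounds were tested in a functional assay on cells (Erythrocyte, Rattus norvegicus) for inhibition, read by hemolysis, with a stated time of 1 h; on this read-out higher numbers stand for weaker inhibition and lower numbers for stronger inhibition. On the numbers shown, compound 1 stands second highest of three, nearest to compound 3 and furthest from compound 2, with both gaps within the scatter; the three values are indistinguishable.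

The unmeasured compound 4 `COc1ccc(C(=O)/C=C/c2cc(OC)c(OC)cc2OC)cc1` is reached from compound 1 by one change: 4-methoxyphenyl in place of 5-chloro-2-hydroxyphenyl on a carbonyl carbon. Among the compounds with values here, no measured step covers this exact pair. Within the data shown here, the one step that bears on it, a 1.0-fold lower number from compound 2 to compound 3 (0.02 log units; within the scatter), alters the same ring, and compound 1 with its own distinct ring on that carbonyl carbon sits at the same level as compounds 2 and 3. The only evidence available therefore points to the ring on the carbonyl carbon having no visible effect in this assay among these compounds.

Compound 4 is accordingly expected to show no step beyond the scatter, a 1.0-fold higher number from compound 1 to compound 4 (0.01 log units; within the scatter). The estimate for compound 4 is 2.3 ug/mL, within 1.2 ug/mL to 4.5 ug/mL.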

Compound 4, half-maximal inhibitory concentration: 2.18 ug/mL
For compound 4 the middle estimate is 1.1-fold (0.02 log units) above the measured one, within the range that was stated.
By their numbers in this assay, from the lowest: compounds 4, 3, 1 and 2 (each within the scatter of the next).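

In this assay, the exchange of 5-chloro-2-hydroxyphenyl for 4-methoxyphenyl on the carbonyl carbon gives a 1.0-fold lower number from compound 1 to compound 4 (0.01 log units; within the scatter), so this position now has a direct comparison involving compound 1. The earlier step only exchanged trifluoromethyl for nitro on an aromatic carbon, whereas this one removes the chlorine and the hydrogen-bond donor together and still leaves the number within the scatter. No supporting measurement explains why the read-out holds steady across this change.

On these data alone, whether an amine or a carboxylic acid on this ring, or a longer chain in its place on the carbonyl carbon, would move the number remains open. Also open, as far as these compounds go, is whether any change to the shared core would show a step beyond the scatter in this assay.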